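Repositioning methoxy groups on the aryl amine

The compounds below may be only part of what the source reports. "The series", "measured", "known", "first", "only" and "open" are said of these compounds alone.

Three compounds sharing one core were tested in a functional assay on PC-3 cells (Homo sapiens) for cytotoxicity, read by MTT assay, with a stated time of 72 h; on this read-out higher numbers stand for weaker inhibition and lower numbers for stronger inhibition. Compound 1 `FC(F)(F)c1ccc(CSc2nc(N3CCCCC3)c3ccccc3n2)cc1` gives 25500 nM. Compound 2 `FC(F)(F)c1ccc(CSc2nc(Nc3ccccc3C(F)(F)F)c3ccccc3n2)cc1` gives 34800 nM in this assay, and compound 3 `COc1ccc(Nc2nc(SCc3ccc(C(F)(F)F)cc3)nc3ccccc23)c(OC)c1` gives 32500 nM. All steps are flat: a 1.4-fold higher number from compound 1 to compound 2 (0.14 log units; within the scatter), a 1.3-fold higher number from compound 1 to compound 3 (0.11 log units; within the scatter) and a 1.1-fold lower number from compound 2 to compound 3 (0.03 log units; within the scatter). Compound 3 thus sits among numbers that cannot be told apart, nearest compound 2 and furthest from compound 1. Compound 4 `COc1ccc(Nc2nc(SCc3ccc(C(F)(F)F)cc3)nc3ccccc23)cc1OC` has the same atoms as compound 3, joined differently: 3,4-dimethoxyphenyl in place of 2,4-dimethoxyphenyl on a nitrogen on an aromatic ring. For the measured compounds named here, the only step bearing on this, the exchange of aryl groups on that nitrogen from compound 2 to compound 3, stayed within the scatter. No step beyond the scatter is therefore expected, giving a 1.0-fold lower number from compound 3 to compound 4 (0.01 log units; within the scatter). Compound 4 is estimated at 32000 nM, ranging from 16000 nM to 64000 nM.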

Compound 4, half-maximal inhibitory concentration: 14100 nM
Compound 4: middle estimate off by 2.3-fold (0.36 log units), on the high side; measured number outside the range, below it.
By their numbers in this assay, from the lowest: compounds 4, 1, 3 and 2 (each within the scatter of the next, the first and the last beyond it).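

Exchanging 2,4-dimethoxyphenyl for 3,4-dimethoxyphenyl on the nitrogen gives, in this assay, a modest step beyond the scatter, a 2.3-fold lower number from compound 3 to compound 4 (0.36 log units; beyond the scatter), so the arrangement of the two methoxy groups matters at this position, which earlier exchanges had not shown. The 3,4-dimethoxyphenyl group also separates from 2-(trifluoromethyl)phenyl, a 2.5-fold lower number from compound 2 to compound 4 (0.39 log units; beyond the scatter), while the step against piperidin-1-yl, a 1.8-fold lower number from compound 1 to compound 4 (0.26 log units; within the scatter), stays within the scatter. Nothing measured here offers a reason for this shift. As far as these compounds go, whether a single methoxy group, or a hydroxyl group or chlorine in place of the methoxy groups, would give a similar number stays open.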